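This account rests on a few compounds, and the source may have more. Where it says the series, first, only, none or still open, it means among the compounds named here.

Working notes on the series.

Compound 1 `Cc1ccc(-c2nn(-c3ccccc3)cc2C(=O)NOCc2ccccc2)cc1` is the reference of the set; in a functional assay on MCF7 cells (Homo sapiens) for antiproliferative activity, read by MTT assay, with a stated time of 48 h, in the presence of a further agent that is not named here (a higher number here means a weaker inhibitor of growth, a lower number a stronger inhibitor of growth), compound 1 gives 1870 nM. Compound 2 `Cc1ccc(-c2nn(-c3ccccc3)cc2C(=O)NOCc2ccccc2F)cc1` carries the change (fluoro in place of hydrogen on an aromatic carbon); in this assay compound 2 gives 2110 nM, and the step is a 1.1-fold higher number from compound 1 to compound 2 (0.05 log units; within the scatter). The two numbers therefore cannot be ordered against each other.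

Compound 3 `O=C(NOCc1ccccc1)c1cn(-c2ccccc2)nc1-c1ccc(F)cc1` has a different core: the difference from compound 1 is fluoro in place of methyl on an aromatic carbon. In this assay compound 3 gives 15300 nM, with the step of an 8.2-fold higher number from compound 1 to compound 3 (0.91 log units; beyond the scatter). Compound 3 stands with the highest number of the three measured compounds, beyond the scatter against both compound 1 and compound 2.

Compound 4 `O=C(NOCc1ccccc1F)c1cn(-c2ccccc2)nc1-c1ccc(F)cc1` is not yet measured. It differs from compound 3 by fluoro in place of hydrogen on an aromatic carbon, and the place of the change reads word for word as it does between compound 1 and compound 2, so this is the same change, made on the core of compound 3 rather than on the core of compound 1. The only earlier case of this change is a 1.1-fold higher number from compound 1 to compound 2 (0.05 log units; within the scatter), which is within the scatter; whether the change behaves alike on the core of compound 3 cannot be checked from anything else in the set, since it occurs only twice.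

The expectation for compound 4 rests on that single earlier step: the step from compound 3 to compound 4 in this assay is estimated at a 1.1-fold higher number from compound 3 to compound 4 (0.03 log units; within the scatter), set beside a 1.1-fold higher number from compound 1 to compound 2 (0.05 log units; within the scatter). On that basis compound 4 is expected to give about 16500 nM in this assay, with a likely range of 7500 nM to 36000 nM.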

Compound 4, concentration for 50% growth inhibition: 12000 nM
The estimate for compound 4 lay 1.4-fold (0.14 log units) above the measured number; the measured number falls inside the stated range.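

In this assay, the change from benzyl to 2-fluorobenzyl on the core of compound 3, a 1.3-fold lower number from compound 3 to compound 4 (0.11 log units; within the scatter), gives the same reading as on the core of compound 1, so it can be carried between these two cores without a difference that can be told apart: the same change on two cores in this assay, a 1.1-fold higher number (0.05 log units; within the scatter) from compound 1 to compound 2 and a 1.3-fold lower number (0.11 log units; within the scatter) from compound 3 to compound 4, 1.4-fold (0.16 log units) apart, within the scatter of two such steps

The exchange of methyl for fluoro, a 5.7-fold higher number from compound 2 to compound 4 (0.75 log units; beyond the scatter), also keeps its direction and size when the benzyloxy group is replaced by (2-fluorobenzyl)oxy: the same change on two cores in this assay, an 8.2-fold higher number (0.91 log units; beyond the scatter) from compound 1 to compound 3 and a 5.7-fold higher number (0.75 log units; beyond the scatter) from compound 2 to compound 4, 1.4-fold (0.16 log units) apart, within the scatter of two such steps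

Both comparisons rest on the same four values, so they are not independent, and they show agreement only within this set of four compounds, not a general rule for other cores or other substituents, and they give no reason for the agreement.

The compounds shown leave open whether a group other than fluoro on the benzyl ring, such as chloro, methoxy or trifluoromethyl, would carry over between these cores in the same way. They also leave open what an amine, a carboxylic acid or a longer chain in place of the methyl or fluoro on the other aromatic ring would do to the growth inhibition, and whether any such replacement would reach below the number of compound 1.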